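This account rests on a few compounds, and the source may have more. Where it says the series, first, only, none or still open, it means among the compounds named here.

Measured compounds:

Compound 1 `CCc1ccc(NC(=O)Nc2cc(C)nc3ccccc23)cc1`: in an ADME assay on BJ cells (Homo sapiens) for cytotoxicity, with a stated time of 72 h (a higher number here means that more compound is needed for the effect, a lower number that less compound is needed), compound 1 gives > 25000 nM, which is a limit of the assay and not a number.
Compound 2 `COc1ccc(NC(=O)Nc2cc(C)nc3ccccc23)cc1F`: in this assay compound 2 gives 26000 nM.
Compound 3 `Cc1cc(NC(=O)Nc2cccc3nsnc23)c2ccccc2n1`: in this assay compound 3 gives > 25000 nM, again a limit of the assay rather than a number.

Among the compounds with values here, compound 1 thus stands at the limit of > 25000 nM in this assay, at which 2 of the 3 values shown sit; it offers no number of its own, and the one numeric value in the set, that of compound 2, sits within the usual scatter of that same limit. All three measured compounds share a core, and none of them shows a cytotoxic effect below the top of the tested range.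

The unmeasured compound 4 `Cc1cc(NC(=O)Nc2ccc(Cl)cc2)c2ccccc2n1` differs from compound 1 in one place: chloro in place of ethyl on an aromatic carbon. Within the data shown here, no step between two measured compounds is available to weigh this change against. With every measured value at or around the limit, no step beyond the scatter is expected in this assay, in either direction. The step of a number no higher from compound 1 to compound 4 (the limit leaves the size open) is therefore estimated as none beyond the scatter. Compound 4 is expected to give about 25000 nM, with a range from 12000 nM to 50000 nM, and most likely the assay will once more report only a limit.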

Compound 4, half-maximal effective concentration: > 25000 nM
Compound 4: no number, only a limit; the forecaster's own chance of this, stated with the estimate: 75%; the middle value lies on the limit itself.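

In this assay compound 4 gives > 25000 nM, a limit of the assay and not a number. With compound 1 also resting on a limit, no step from compound 1 to compound 4 can be read: the limit of > 25000 nM in this assay, at which 3 of the 4 values shown sit.

The compounds shown leave open how chloro and ethyl compare, and whether any change to the shared core would yield a readable cytotoxic value.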